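Dropping the methoxy from the aryl ether of compound 3

The source may hold more compounds than are shown below. What is called first, only, known or untested is meant among the compounds shown, and "the series" means these compounds.

Measured so far:
compound 1 `Cc1c(OCCCCOc2ccc(F)c(C(=O)O)c2)ccc(C(=O)CC2CCCC2)c1O`: 98.4%
compound 2 `Cc1cc(OCCCCOc2ccc(C(=O)CC3CCCC3)c(O)c2C)ccc1C(=O)O`: 23.7%
compound 3 `COc1ccc(C(=O)O)cc1OCCCCOc1ccc(C(=O)CC2CCCC2)c(O)c1C`: 67.6%

In an assay on HEK293 cells for positive allosteric modulation of metabotropic glutamate receptor 3 (Rattus norvegicus), read by thallium flux, with a stated time of 2.5 min (on this read-out lower numbers stand for smaller maximal responses and higher numbers for larger maximal responses), compound 3 stands second highest of the three values, with compound 1 nearest and compound 2 furthest. The two steps that reach compound 3 were both large: a number 30.8 percentage points lower from compound 1 to compound 3 (beyond the scatter) and a number 43.9 percentage points higher from compound 2 to compound 3 (beyond the scatter). So the aryl group on the ether oxygen of the chain moves the read-out strongly in this series.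

Compound 4 `Cc1c(OCCCCOc2cccc(C(=O)O)c2)ccc(C(=O)CC2CCCC2)c1O` differs from compound 3 by hydrogen in place of methoxy on an aromatic carbon. For the measured compounds named here, no measured step removes a methoxy from this aryl group, so none bears on the change directly; the measured steps only show that alterations at this aryl group can be large. Compound 1, which also carries no methoxy, gives 98.4%. A modest rise is therefore expected, a number 12.4 percentage points higher from compound 3 to compound 4 (beyond the scatter), and compound 4 is estimated at 80%, in a range from 50% to 105%.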

Compound 4, largest response reached (reported as percent of maximum), in percent of the reference or control that the assay uses: 92.9%
Compound 4: the middle estimate sits 12.9 percentage points below what was measured; measured number inside the range.
By their numbers in this assay, from the lowest: compound 2; then compound 3; then compounds 4 and 1 (each within the scatter of the next).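

In this assay, the methoxy that sits ortho to a large group and para to a carboxy group proves dispensable, and losing it raises the maximal response: a number 25.3 percentage points higher from compound 3 to compound 4 (beyond the scatter). The 3-carboxyphenyl group also stands far from the 4-carboxy-3-methylphenyl group, with a number 69.2 percentage points higher from compound 2 to compound 4 (beyond the scatter), so this plain aryl group keeps the high response without any further substituent. Adding fluoro gives no distinguishable change, with a number 5.5 percentage points lower from compound 1 to compound 4 (within the scatter), so compound 1 and compound 4 cannot be ranked on this read-out.

Nothing given here explains these steps. Still open, from the compounds shown here alone, is how a methyl or a chlorine would behave in the place of the methoxy, and whether a tetrazole or a primary amide could stand in for the carboxylic acid on the 3-carboxyphenyl group.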